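Moving the fluorine on the sulfonyl aryl ring

The compounds below may be only part of what the source reports. "The series", "measured", "known", "first", "only" and "open" are said of these compounds alone.

Compound 3 `COc1ccc(-c2c(S(=O)(=O)c3cccc(F)c3)cnc3cc(F)ccc23)cc1` carries a 3-fluorophenyl on its sulfonyl sulfur. In an ADME assay on microsomes from liver (Homo sapiens) for metabolic stability, tested at 2.5 uM (a lower number here means slower removal, a higher number faster removal of the compound), compound 3 gives 1.89 mL/min, the highest of the three numbers, though both of its gaps to the others fall within the scatter. Compound 1 `COc1ccc(-c2c(S(=O)(=O)c3cc(F)cc(F)c3)cnc3cc(F)ccc23)cc1` gives 1.51 mL/min in this assay, and compound 2 `O=S(=O)(c1ccc(F)cc1)c1cnc2cc(F)ccc2c1-c1ccc(Cl)cc1` gives 1.23 mL/min. Among the measured compounds shown here, the only one-point step measured so far, a 1.3-fold higher number from compound 1 to compound 3 (0.10 log units; within the scatter), puts hydrogen in place of fluoro on an aromatic carbon and stays within the scatter. Compound 4 `COc1ccc(-c2c(S(=O)(=O)c3ccc(F)cc3)cnc3cc(F)ccc23)cc1` differs from compound 3 as follows: 4-fluorophenyl in place of 3-fluorophenyl on a sulfonyl sulfur. For the measured compounds named here, no measured step moves a fluorine from one position to another on this ring, so that single step is the nearest guide, and it was small. Compound 2, which also carries a 4-fluorophenyl on its sulfonyl sulfur, sits within the scatter of compound 3. Compound 4 is therefore expected to show a 1.2-fold lower number from compound 3 to compound 4 (0.07 log units; within the scatter), nothing beyond the scatter. The estimate for compound 4 is 1.6 mL/min, between 1 mL/min and 2.6 mL/min.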

Compound 4, intrinsic clearance in a liver preparation (reported as CLH), per the amount of preparation that the assay uses: 1.77 mL/min
Compound 4: middle estimate off by 1.1-fold (0.04 log units), on the low side, within the range that was stated.
By their numbers in this assay, from the lowest: compounds 2, 1, 4 and 3 (each within the scatter of the next).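

Moving the fluorine, with 4-fluorophenyl in place of 3-fluorophenyl on a sulfonyl sulfur, gives a 1.1-fold lower number from compound 3 to compound 4 (0.03 log units; within the scatter) in this assay, so the first measured shift of this fluorine leaves the number within the scatter. Changing the fluorine pattern on the same ring gives a 1.2-fold higher number from compound 1 to compound 4 (0.07 log units; within the scatter) and likewise stays within the scatter, matching the earlier hydrogen-for-fluoro step. With the 4-fluorophenyl kept, methoxy in place of chloro on an aromatic carbon gives a 1.4-fold higher number from compound 2 to compound 4 (0.16 log units; within the scatter) and also stays within the scatter, so this change elsewhere in the compound shows no clear effect either.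

Nothing in the data at hand accounts for how small these steps are. The compounds shown leave open whether an amine or a carboxylic acid on the sulfonyl aryl ring would move the number beyond the scatter.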